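Furan-3-yl for a substituted phenyl: a thiazole acetic acid series

A few compounds are considered here, and "the series" means these few. Any claim that something is new, unique, unknown or untested is made for them only; others in the source may bear on it.

Compound 1 `O=C(O)Cc1sc(C(c2ccc(F)cc2)c2ccc(F)cc2)nc1-c1ccccc1`, 16 nM; compound 2 `NS(=O)(=O)c1cccc(-c2nc(C(c3ccc(F)cc3)c3ccc(F)cc3)sc2CC(=O)O)c1`, 140 nM; compound 3 `CS(=O)(=O)Nc1cccc(-c2nc(C(c3ccc(F)cc3)c3ccc(F)cc3)sc2CC(=O)O)c1`, 40 nM.

These three compounds share one core and differ only in the aryl group attached to it. In an in vitro assay on HEK385-7 cells for displacement of a labelled ligand from prostaglandin D2 receptor 2 (Homo sapiens) (on this read-out lower numbers stand for stronger inhibition and higher numbers for weaker inhibition), compound 3 gives the second highest of the three values: compound 1 lies below it by a 2.5-fold higher number from compound 1 to compound 3 (0.40 log units; beyond the scatter), and compound 2 lies above it by a 3.5-fold lower number from compound 2 to compound 3 (0.54 log units; beyond the scatter). Compound 4 `O=C(O)Cc1sc(C(c2ccc(F)cc2)c2ccc(F)cc2)nc1-c1ccoc1` has not yet been measured. It differs from compound 3 in this way: furan-3-yl in place of 3-(methanesulfonamido)phenyl on an aromatic carbon.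

Going by the values given here, no measured step replaces the whole phenyl ring by another ring, so the measured steps bear only indirectly on this change. The step from compound 1 to compound 3 shows that adding the methanesulfonamido group cost a modest amount; removing it again should recover part of that, but the furan ring itself is uncharted. Compound 4 is therefore expected to land between compound 1 and compound 3, with a step of a 1.6-fold lower number from compound 3 to compound 4 (0.20 log units; within the scatter). The estimate for compound 4 in this assay is 25 nM, within a range of 8 nM to 80 nM.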

Compound 4, half-maximal inhibitory concentration: 14 nM
Beside the measured number, compound 4's estimate is 1.8-fold (0.25 log units) above it, within the range that was stated.
By their numbers in this assay, from the lowest: compounds 4 and 1 (each within the scatter of the next); then compound 3; then compound 2.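

The change shows that the aryl position next to the ring nitrogen need not carry a six-membered ring of carbon: in this assay furan-3-yl in place of phenyl gives a number that the scatter does not separate (a 1.1-fold lower number from compound 1 to compound 4 (0.06 log units; within the scatter)). The smaller ring also gives a lower number than either substituted phenyl, beyond the scatter in both cases (a 2.9-fold lower number from compound 3 to compound 4 (0.46 log units; beyond the scatter); a 10-fold lower number from compound 2 to compound 4 (1.00 log units; beyond the scatter)). Among these compounds, then, the two rings without a substituent sit together, and compound 3 and compound 2 each give a higher number than furan-3-yl.

On these data alone, whether thiophen-3-yl or a pyridine ring would match furan-3-yl, and whether methanesulfonamido on the furan ring would cost what it costs on phenyl, stays open. No measurement at hand explains these differences.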